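Aryl-thiazole carboxylic acids: pyrimidinyl replacing thiophenyl

A few compounds are considered here, and "the series" means these few. Any claim that something is new, unique, unknown or untested is made for them only; others in the source may bear on it.

Measured compounds:
compound 1 `O=C(O)c1csc(-n2nc(-c3cccc(F)c3)c3ccccc32)n1`, 20 nM
compound 2 `O=C(O)c1csc(-n2nc(-c3ccsc3)c3ccccc32)n1`, 30 nM

Both compounds share the same fused core and thiazole carboxylic acid and differ only in the aromatic group on the fused ring. In an assay on isolated protein for antagonist activity at prostaglandin E2 receptor EP1 subtype (Homo sapiens), read by reporter gene assay (on this read-out higher numbers stand for weaker inhibition and lower numbers for stronger inhibition), compound 1 gives 20 nM and compound 2 gives 30 nM; the two numbers sit within the scatter of one another, so neither compound can be set apart from the other on this read-out. Going by the values given here, the only step measured, a 1.5-fold higher number from compound 1 to compound 2 (0.18 log units; within the scatter), shows that exchanging one aromatic group for another at this position left the number essentially unchanged.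

Compound 3 `O=C(O)c1csc(-n2nc(-c3cncnc3)c3ccccc32)n1` is not yet measured. Relative to compound 2 the change is pyrimidin-5-yl in place of thiophen-3-yl on an aromatic carbon. Among the compounds with values here, no measured step covers a six-membered ring with two nitrogens at this position, so the single step from compound 1 to compound 2 is the only guide, and it was within the scatter. On that basis no step beyond the scatter is expected in this assay, with the uncertainty widened because the new group is of a different kind from either measured one. The expected step is a 1.7-fold higher number from compound 2 to compound 3 (0.22 log units; within the scatter). For compound 3 the estimate in this assay is 50 nM, with a range from 15 nM to 200 nM.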

Compound 3, half-maximal inhibitory concentration: > 100 nM
Compound 3 ended at the assay's limit; the forecaster's own chance of this, stated with the estimate: 5%; middle value at least 2.0-fold (0.30 log units) away from the limit.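

In this assay compound 3 stands at a limit of the assay and not at a number: the limit of > 100 nM in this assay, at which 1 of the 3 values shown sits.

This position is not indifferent to the group it carries, as the earlier pair alone suggested: pyrimidin-5-yl gives an at least 3.3-fold higher number from compound 2 to compound 3 (0.52 log units; beyond the scatter) and, against the other measured group, an at least 5.0-fold higher number from compound 1 to compound 3 (0.69 log units; beyond the scatter), both beyond the scatter. Ring size alone does not separate these groups, as compound 1 also carries a six-membered aromatic ring and stays within the scatter of compound 2, which carries a five-membered one.

Still open, as far as these compounds go, is whether a single ring nitrogen, as in pyridin-3-yl, already gives a step of this kind or whether both ring nitrogens of pyrimidin-5-yl are needed. Also open, from the compounds shown here alone, are the true size of both steps, which the limit leaves without an upper end, and how a phenyl ring bearing a methoxy group or an amine would read at this position in this assay.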